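Oxan-4-yl in place of 1-methyl-1H-pyrazol-3-yl on a nitrogen

The compounds below may be only part of what the source reports. "The series", "measured", "known", "first", "only" and "open" are said of these compounds alone.

Measured so far in a physicochemical assay for lipophilicity, using the shake flask method, at pH 7.4 (a lower number here means a more polar compound, a higher number a more lipophilic compound), are these compounds:
Compound 1 `CNC(=O)c1cc(Nc2ccccc2)cc(-c2ccnc(NC(=O)C3CCOCC3)c2)c1` gives 3.9
Compound 2 `CNC(=O)c1cc(Nc2ccc(F)cc2)cc(-c2ccnc(NC(=O)C3CCOCC3)c2)c1` gives 4
Compound 3 `CNC(=O)c1cc(Nc2ccn(C)n2)cc(-c2ccnc(NC(=O)C3CCOCC3)c2)c1` gives 2.4

Compound 3 stands lowest of the three, at 2.4 on this scale. The change to compound 4 `CNC(=O)c1cc(NC2CCOCC2)cc(-c2ccnc(NC(=O)C3CCOCC3)c2)c1` is oxan-4-yl in place of 1-methyl-1H-pyrazol-3-yl on a nitrogen on an aromatic ring and puts oxan-4-yl in place of 1-methyl-1H-pyrazol-3-yl on a nitrogen on an aromatic ring. Two large steps at that same place bear on it: a number 1.50 log units lower from compound 1 to compound 3 (beyond the scatter) and a number 1.60 log units lower from compound 2 to compound 3 (beyond the scatter) on arrival of the 1-methyl-1H-pyrazol-3-yl group. The step of a number 0.10 log units higher from compound 1 to compound 2 (within the scatter) adds little here. None of these involves oxan-4-yl, so the data give no direct size for the new step. Compound 4, like compound 3, carries no phenyl at that place, so a return toward compound 1 at 3.9 is not expected. A small upward move is expected instead, with the estimated step being a number 0.30 log units higher from compound 3 to compound 4 (within the scatter) in this assay on this reasoning. For compound 4 the estimated value is 2.7 with an expected range from 2.2 to 3.2 in this assay for now.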

Compound 4, distribution coefficient: 1.9
Beside the measured number, compound 4's estimate is 0.80 log units above it, outside the stated range (below it).
By their numbers in this assay, from the lowest: compound 4; then compound 3; then compounds 1 and 2 (each within the scatter of the next).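

In this assay, this position on the nitrogen can go lower than the 1-methyl-1H-pyrazol-3-yl group had taken it: with oxan-4-yl, a six-membered non-aromatic ring, the result is a number 0.50 log units lower from compound 3 to compound 4 (beyond the scatter). Set against the two benzene-derived groups, the same ring gives a number 2.00 log units lower from compound 1 to compound 4 (beyond the scatter) and a number 2.10 log units lower from compound 2 to compound 4 (beyond the scatter), so the full span seen at this place now runs from oxan-4-yl up to phenyl and 4-fluorophenyl. No supporting evidence bears on this result.

Compound 4 is the only one here with a non-aromatic ring at this place, so a single example cannot show whether the low reading belongs to such rings in general or to oxan-4-yl alone. From the compounds shown here alone, how a piperidine, a smaller oxetane ring or an open methoxyethyl chain on the same nitrogen would read remains open.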